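This account rests on a few compounds, and the source may have more. Where it says the series, first, only, none or still open, it means among the compounds named here.

Compound 1 `CCCCC(=O)NCCCCc1cccc(OC)c1` gives 9670 nM in an assay for binding affinity to melatonin receptor (Gallus gallus); on this read-out higher numbers stand for weaker inhibition and lower numbers for stronger inhibition. Compound 2 `CCC(=O)NCCCc1cccc(F)c1` gives 740 nM in this assay, and compound 3 `CCCC(=O)NCCCc1cccc(F)c1` gives 434 nM. Among these three numbers compound 2 stands second highest. The nearest number is reached by a 1.7-fold lower number from compound 2 to compound 3 (0.23 log units; within the scatter), a change on the amide chain. Among the measured compounds shown here, the furthest is that of compound 1, which lies beyond the scatter above the number of compound 2; the two structures differ in more than one place, and no single step links them.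

Compound 4 `CCC(=O)NCCCc1cccc(Br)c1` is not yet measured. It differs from compound 2 by bromo in place of fluoro on an aromatic carbon. For the measured compounds named here, no measured step touches the substituent on the aromatic ring: the one step in hand alters the amide chain and is itself within the scatter. Nothing measured therefore bears directly on this change, and no step beyond the scatter is expected in this assay from exchanging one halogen for another at the same ring carbon. For compound 4 the estimate is 450 nM, with a range from 120 nM to 1800 nM. This estimate means the step of a 1.6-fold lower number from compound 2 to compound 4 (0.22 log units; within the scatter), which is expected to remain within the scatter.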

Compound 4, inhibition constant: 318 nM
Compound 4: middle estimate off by 1.4-fold (0.15 log units), on the high side; measured number inside the range.
By their numbers in this assay, from the lowest: compounds 4, 3 and 2 (each within the scatter of the next, the first and the last beyond it); then compound 1.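

Exchange of fluoro for bromo on the aromatic carbon gives the first measured step at this ring position in this assay, namely a 2.3-fold lower number from compound 2 to compound 4 (0.37 log units; beyond the scatter) and modest in size. It is also the only single-place step shown so far that lies beyond the scatter, whereas the one earlier step, a 1.7-fold lower number from compound 2 to compound 3 (0.23 log units; within the scatter) on the amide chain, stays within it, so the substituent on this ring carbon is the one place where a single change has been seen to shift the number. Nothing measured here accounts for the size or direction of this step.

As far as these compounds go, the finding rests on one pair of halogens on one amide chain, so it remains open whether chloro, iodo, trifluoromethyl or an amine at the same ring carbon would continue the step from fluoro to bromo or break from it. From the compounds shown here alone, it also remains open whether the same exchange would give a step of similar size on the longer amide chain of compound 3, or when the substituent stands at another carbon of the ring.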